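Side chain variation at the ester-bearing carbon

The source may hold more compounds than are shown below. What is called first, only, known or untested is meant among the compounds shown, and "the series" means these compounds.

Compound 1 `NC(=O)C[C@H](NC(=O)CN(c1ncnc2c1ncn2C1CCCCO1)C1CC1)C(=O)OCc1ccccc1` and compound 2 `CSCC[C@H](NC(=O)CN(c1ncnc2c1ncn2C1CCCCO1)C1CC1)C(=O)OCc1ccccc1` share one core and differ only in the group on the saturated chain carbon. In a functional assay on the whole organism (Tail, strain ICR) with Mus musculus as the target, in the tail flick test, with a stated time of 150 min, at a dose of 25 umol/kg by the oral route (a lower number here means a weaker effect, a higher number a stronger effect of the compound at the dose given), compound 1 gives 21.7%. In this assay compound 2 gives 17.5%; the step of a number 4.2 percentage points lower from compound 1 to compound 2 (within the scatter) lies within the scatter, so compound 2 stands level with compound 1 on the two numbers shown and neither can be called the stronger.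

Compound 3 `CC(C)[C@H](NC(=O)CN(c1ncnc2c1ncn2C1CCCCO1)C1CC1)C(=O)OCc1ccccc1` is not yet measured. It differs from compound 2 as follows: isopropyl in place of 2-(methylsulfanyl)ethyl on a saturated chain carbon bound to an amide-type nitrogen and a carbonyl carbon. For the measured compounds named here, the only step that bears on this change is the one from compound 1 to compound 2, which also exchanged the group at this chain carbon and moved the read-out by a number 4.2 percentage points lower from compound 1 to compound 2 (within the scatter), within the scatter. On that basis no step beyond the scatter is expected from compound 2 to compound 3, and the estimated step is a number 0.5 percentage points higher from compound 2 to compound 3 (within the scatter). Compound 3 is therefore estimated at 18%, with a range from 7% to 31%.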

Compound 3, a percentage reported as activity, at one dose (the size of the read-out at that dose, not a potency): 21.1%
Compound 3: the middle estimate sits 3.1 percentage points below what was measured, and the stated range covers the measured number.
By their numbers in this assay, from the lowest: compounds 2, 3 and 1 (each within the scatter of the next).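

In this assay, isopropyl in place of 2-(methylsulfanyl)ethyl on a saturated chain carbon bound to an amide-type nitrogen and a carbonyl carbon gives a number 3.6 percentage points higher from compound 2 to compound 3 (within the scatter) and isopropyl in place of carbamoylmethyl at that carbon gives a number 0.6 percentage points lower from compound 1 to compound 3 (within the scatter) so all three compounds stand level. The earlier pair compared only a sulfur-bearing group with a carbamoyl-bearing one, whereas isopropyl holds carbon only, so in these compounds neither the sulfur atom nor the carbamoyl group is required for a read-out at this level at the dose given. No measurement on these groups is at hand that could account for this result.

The shared core and benzyl ester stay fixed throughout, and only three groups are shown at this carbon, so it remains open whether an amine, a carboxylic acid or a longer chain there would move the read-out beyond the scatter. Going by these compounds, with a single dose and a single time point, it also remains open whether these level read-outs would stay level at other doses or times.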